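Swapping a fluoro for a methyl on the aryl ring

The compounds below may be only part of what the source reports. "The series", "measured", "known", "first", "only" and "open" are said of these compounds alone.

Measured compounds and their values:
Compound 1, `CC1=C(/C=C/C(=O)/C=C/c2cccc(C(F)(F)F)c2)C(C)(C)CCC1O`: 1700 nM
Compound 2, `CC1=C(/C=C/C(=O)/C=C/c2ccccc2F)C(C)(C)CCC1O`: 3300 nM
Compound 3, `CC1=C(/C=C/C(=O)/C=C/c2cccc(F)c2)C(C)(C)CCC1O`: 5600 nM

All three share the same core and differ only in the substituent on the aromatic ring. In a functional assay on CWR22R cells (Homo sapiens) for cytotoxicity, read by MTT assay, with a stated time of 72 h (on this read-out lower numbers stand for stronger inhibition and higher numbers for weaker inhibition), compound 3 gives the highest of the three numbers; its nearest neighbour is compound 2, and the step of a 1.7-fold higher number from compound 2 to compound 3 (0.23 log units; within the scatter) is small, while the step of a 3.3-fold higher number from compound 1 to compound 3 (0.52 log units; beyond the scatter) is larger.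

Compound 4, `CC1=C(/C=C/C(=O)/C=C/c2cccc(C)c2)C(C)(C)CCC1O`, has not yet been measured. It arises from compound 3 by the change (methyl in place of fluoro on an aromatic carbon), that is, on an aromatic carbon of a six-membered aromatic ring of carbon only, meta to a large group.

For the measured compounds named here, no measured pair swaps fluoro for methyl, so the bearing steps are indirect. The step of a 3.3-fold higher number from compound 1 to compound 3 (0.52 log units; beyond the scatter) shows that exchanging the group at this same place can move the number by a modest amount beyond the scatter, whereas a 1.7-fold higher number from compound 2 to compound 3 (0.23 log units; within the scatter) shows that moving the fluoro around the ring barely matters. A change of similar or smaller size than the first is therefore expected for compound 4 in this assay, with the direction uncertain; the estimate is a 1.6-fold lower number from compound 3 to compound 4 (0.20 log units; within the scatter). Compound 4 is estimated at 3500 nM, between 1200 nM and 10000 nM.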

Compound 4, half-maximal inhibitory concentration: 4400 nM
Estimate against measurement, compound 4: 1.3-fold (0.10 log units) below; the range from low to high includes it.
By their numbers in this assay, from the lowest: compounds 1, 2, 4 and 3 (each within the scatter of the next, the first and the last beyond it).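

In this assay, the direct exchange of fluoro for methyl at this place on the ring gives a 1.3-fold lower number from compound 3 to compound 4 (0.10 log units; within the scatter), so the assay does not tell these two groups apart. Changing both the group and its place, from 2-fluorophenyl to 3-methylphenyl, gives a 1.3-fold higher number from compound 2 to compound 4 (0.12 log units; within the scatter) and also leaves the two compounds indistinguishable, whereas exchanging trifluoromethyl for methyl gives a 2.6-fold higher number from compound 1 to compound 4 (0.41 log units; beyond the scatter), so at this place trifluoromethyl now stands apart from both fluoro and methyl. No accompanying measurement offers an explanation for any of these steps.

The compounds shown leave open whether other groups at this place, such as a methoxy group, an amine or a carboxylic acid, would fall with fluoro and methyl or with trifluoromethyl. They also leave open whether a methyl group placed elsewhere on the ring would match the fluoro of compound 2, and so whether the group's place matters more for methyl than it appears to for fluoro.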